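Methoxy Swapped for Methyl on the Benzyl Amide

A few compounds are considered here, and "the series" means these few. Any claim that something is new, unique, unknown or untested is made for them only; others in the source may bear on it.

Of the compounds shown here, three built on one shared core have been measured in an assay on microsomes from liver for inhibition of 3-hydroxy-3-methylglutaryl-coenzyme A reductase (Rattus norvegicus); on this read-out higher numbers stand for weaker inhibition and lower numbers for stronger inhibition. Compound 1 `CC(C)c1c(C(=O)NCC2CCCCC2)nn(-c2ccc(F)cc2)c1OC[C@@H](O)C[C@@H](O)CC(=O)O` gives 17 nM, compound 2 `Cc1ccc(CN(C)C(=O)c2nn(-c3ccc(F)cc3)c(OC[C@@H](O)C[C@@H](O)CC(=O)O)c2C(C)C)cc1` gives 37 nM, and compound 3 `CC(C)c1c(C(=O)N2CCCCC2)nn(-c2ccc(F)cc2)c1OC[C@@H](O)C[C@@H](O)CC(=O)O` gives 47 nM. On these numbers compound 2 stands second highest of the three, nearest to compound 3 and furthest from compound 1. Every measured step alters only the group on the carbonyl carbon: a 2.2-fold higher number from compound 1 to compound 2 (0.34 log units; beyond the scatter), a 2.8-fold higher number from compound 1 to compound 3 (0.44 log units; beyond the scatter), and a 1.3-fold higher number from compound 2 to compound 3 (0.10 log units; within the scatter). Compound 4 `COc1cccc(CN(C)C(=O)c2nn(-c3ccc(F)cc3)c(OC[C@@H](O)C[C@@H](O)CC(=O)O)c2C(C)C)c1` differs from compound 2 at another place: 3-methoxyphenyl in place of 4-methylphenyl on a saturated chain carbon bound to an amide-type nitrogen. For the measured compounds named here, no measured step touches a substituent on that aromatic ring, so no step bears directly on this change, and the expected step of a 1.1-fold higher number from compound 2 to compound 4 (0.03 log units; within the scatter) is none beyond the scatter. Compound 4 is therefore estimated at 40 nM, within a range from 15 nM to 110 nM.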

Compound 4, half-maximal inhibitory concentration: 21 nM
Estimate against measurement, compound 4: 1.9-fold (0.28 log units) above; low and high end bracket the measured number.
By their numbers in this assay, from the lowest: compounds 1, 4, 2 and 3 (each within the scatter of the next, the first and the last beyond it).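

In this assay the exchange of 4-methylphenyl for 3-methoxyphenyl on a saturated chain carbon bound to an amide-type nitrogen gives a 1.8-fold lower number from compound 2 to compound 4 (0.25 log units; within the scatter) and so stays inside the usual scatter at this position. With the new ring, the amide still differs from the piperidin-1-yl amide, with a 2.2-fold lower number from compound 3 to compound 4 (0.35 log units; beyond the scatter) as the step, and it stays close to the (cyclohexylmethyl)amino amide, with a 1.2-fold higher number from compound 1 to compound 4 (0.09 log units; within the scatter) as the step. Nothing measured here explains these numbers. The two compounds differ in both the substituent and its ring position, so the effects of each cannot be separated. As far as these compounds go, whether 3-methylphenyl or 4-methoxyphenyl would sit with these values remains open.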